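Aryl tail changes in the shared-core series

The source may report more compounds than this note shows. Statements on the series, on what has been measured and on what is new or still open speak of the compounds shown alone.

Among the compounds with values here, compound 3 `O=C(CCCCCCc1cccc(Cl)c1Cl)c1ncc(-c2ccccn2)o1` is the only member of this set with a number in an assay for inhibition of Fatty-acid amide hydrolase 1 (Rattus norvegicus); on this read-out higher numbers stand for weaker inhibition and lower numbers for stronger inhibition; compound 3 gives 0.9 nM. Compound 1 `O=C(CCCCCCc1ccccc1C(=O)O)c1ncc(-c2ccccn2)o1` gives > 600 nM, a limit of the assay. Compound 2 `O=C(O)c1cccc(CCCCCCC(=O)c2ncc(-c3ccccn3)o2)c1` gives > 600 nM, likewise a limit (the limit of > 600 nM in this assay, at which 2 of the 3 values shown sit). Between them the step that the two limits leave unreadable from compound 1 to compound 2 cannot be sized. Compound 4 `Nc1ccc(CCCCCCC(=O)c2ncc(-c3ccccn3)o2)cc1` is not yet measured; it differs from compound 3 by 4-aminophenyl in place of 2,3-dichlorophenyl on a saturated chain carbon, six bonds along the chain from a carbonyl carbon. The measured steps of an at least 660-fold lower number from compound 1 to compound 3 (2.82 log units; beyond the scatter) and an at least 660-fold lower number from compound 2 to compound 3 (2.82 log units; beyond the scatter) both run toward the 2,3-dichlorophenyl, and the step to compound 4 runs away from that group, so a large step toward a higher number is expected, a 110-fold higher number from compound 3 to compound 4 (2.05 log units; beyond the scatter). Compound 4 is estimated at 100 nM, with a range from 10 nM to 600 nM.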

Compound 4, inhibition constant: 3 nM
Compound 4: the middle estimate sits 33-fold (1.52 log units) above what was measured, and the stated range ends above it.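

At the chain end, chlorine is not required for a low number in this assay: 4-aminophenyl in place of 2,3-dichlorophenyl gives only a 3.3-fold higher number from compound 3 to compound 4 (0.52 log units; beyond the scatter). The 4-aminophenyl tail also stays far from both carboxyphenyl tails, with an at least 200-fold lower number from compound 2 to compound 4 (2.30 log units; beyond the scatter) and an at least 200-fold lower number from compound 1 to compound 4 (2.30 log units; beyond the scatter), so a substituted phenyl at this position does not by itself bring the weak read-out. Both sizes are lower bounds: the limit of > 600 nM in this assay, at which 2 of the 4 values shown sit.

Still open, going by these compounds, is how much the place of the amine on the ring matters, which 3-aminophenyl would test. On these data alone, a plain phenyl tail and 4-carboxyphenyl also remain open.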